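Adding a fluoro to compound 2

The compounds below may be only part of what the source reports. "The series", "measured", "known", "first", "only" and "open" are said of these compounds alone.

Compound 1 `CCNCC1CCN(c2c(F)cc3c(=O)c(C(=O)O)cn(C4CC4)c3c2F)C1`: 11 ug/mL; 11 ug/mL; 11 ug/mL; 11 ug/mL (4 entries)
Compound 2 `CC1CN(c2cc3c(cc2F)c(=O)c(C(=O)O)cn3C2CC2)CC(C)N1`: > 500 ug/mL, a limit

Both compounds were tested in a functional assay on V79 cells (Cricetulus griseus) for cytotoxicity, read by colony formation; on this read-out lower numbers stand for stronger inhibition and higher numbers for weaker inhibition. Compound 2 stands at > 500 ug/mL in this assay, which is a limit of the assay and not a number. Compound 3 `CC1CN(c2c(F)cc3c(=O)c(C(=O)O)cn(C4CC4)c3c2F)CC(C)N1` is still to be measured. It differs from compound 2 in one place: fluoro in place of hydrogen on an aromatic carbon. This is fluoro in place of hydrogen on an aromatic carbon, ortho to the 3,5-dimethylpiperazin-1-yl group.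

Within the data shown here, no measured pair isolates this change. Compound 1 carries a fluoro on the same carbon and gives 11 ug/mL; 11 ug/mL; 11 ug/mL; 11 ug/mL (4 entries), but it also differs from compound 3 in another place, so it is only a loose guide. A step towards stronger inhibition is therefore expected, with an at least 4.1-fold lower number from compound 2 to compound 3 (0.61 log units; beyond the scatter) as the estimate. For compound 3 the expected value is 120 ug/mL, with an estimated range of 35 ug/mL to 400 ug/mL.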

Compound 3, half-maximal inhibitory concentration: 150 ug/mL
Beside the measured number, compound 3's estimate is 1.3-fold (0.10 log units) below it; the range from low to high includes it.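

In this assay, the fluoro on this aromatic carbon, ortho to the 3,5-dimethylpiperazin-1-yl group, now has a measured pair of its own, which gives an at least 3.3-fold lower number from compound 2 to compound 3 (0.52 log units; beyond the scatter). Until now only compound 1 carried a fluoro there, and because it also differs from compound 3 in another place, the effect of this single change could not be read from it. The step gives only a lower bound on the size of the change, because the value of compound 2 is a limit of the assay and not a number: the limit of > 500 ug/mL in this assay, at which 1 of the 3 values shown sits.

The compounds shown leave open whether chloro or methoxy on the same carbon would give a step of similar size. They also leave open whether the fluoro would give a like step with an unsubstituted piperazine in place of the 3,5-dimethylpiperazin-1-yl group.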